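Turning the side-chain alcohol around on compound 3

The compounds below may be only part of what the source reports. "The series", "measured", "known", "first", "only" and "open" are said of these compounds alone.

Compound 3 `C=C1CC/C=C(\C)CC[C@@H]2[C@H](CC/C=C(\C)CO)C(=O)OC[C@@H]12` is one of three compounds that share the same core and are compared in a functional assay on K562 cells (Homo sapiens) for cytotoxicity; a higher number here means that more compound is tolerated, a lower number that less compound is tolerated. Compound 3 gives 1.2 ug/mL, which places it second highest of the three numbers. Compound 2 `C=C1CC[C@@H]2O[C@@]2(C)CC[C@@H]2[C@H](CC/C=C(\C)C(=O)OC)C(=O)OC[C@@H]12` gives 3.9 ug/mL, a higher number than compound 3 and a gap that lies beyond the scatter. Compound 1 `C=C1CC/C=C(\C)CC[C@@H]2/C(=C\C=C\C(C)(C)O)C(=O)OC[C@@H]12` gives 0.04 ug/mL, far below compound 3, so compound 1 is the least tolerated of the three.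

Compound 4 `C=C1CC/C=C(\C)CC[C@@H]2[C@H](C/C=C/C(C)(C)O)C(=O)OC[C@@H]12` has not yet been measured in this assay. It keeps every atom of compound 3 but joins them differently in the side chain: 3-hydroxy-3-methylbut-1-en-1-yl in place of 3-(hydroxymethyl)but-2-en-1-yl on a saturated chain carbon bound to a saturated ring carbon. The alcohol thus moves from a hydroxymethyl on the double bond to a carbon carrying two methyl groups, the same arrangement found at the end of the side chain of compound 1.

Among the compounds with values here, no measured pair shows what this rearrangement does on its own. Because compound 1 gives 0.04 ug/mL with a related chain end, the expected step is a 1.5-fold lower number from compound 3 to compound 4 (0.18 log units; within the scatter), a small shift toward a lower number that is estimated to stay within the scatter. Compound 4 is therefore estimated at 0.8 ug/mL, within a range from 0.2 ug/mL to 3 ug/mL.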

Compound 4, concentration lethal to 50% of the cells: 2 ug/mL
Compound 4: the middle estimate sits 2.5-fold (0.40 log units) below what was measured; measured number inside the range.
By their numbers in this assay, from the lowest: compound 1; then compounds 3, 4 and 2 (each within the scatter of the next, the first and the last beyond it).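

In this assay, the rearranged side chain gives a 1.7-fold higher number from compound 3 to compound 4 (0.22 log units; within the scatter). Within the data shown here, the two chains hold the same atoms, joined differently, so this pair isolates the arrangement of the alcohol, something the earlier compounds, with no pair differing in one place, could not do. On a saturated chain carbon bound to a saturated ring carbon, 3-hydroxy-3-methylbut-1-en-1-yl and 3-(hydroxymethyl)but-2-en-1-yl cannot be told apart in this read-out, and nothing measured here bears on why.

The compounds shown leave open whether the alcohol itself matters at this position, since both chains carry one and neither a plain alkenyl chain nor a carboxylic acid or amine at the chain end appears among them. As far as these compounds go, it also remains open whether a longer chain would move the number beyond the scatter.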